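A Larger Group on the Amine of Compound 2

The source may hold more compounds than are shown below. What is called first, only, known or untested is meant among the compounds shown, and "the series" means these compounds.

Compound 1 `CCOC(=O)c1cnc(NCCOC)n2nc(-c3ccco3)nc12` in a functional assay on CHO cells for antagonist activity at adenosine receptor A2b (Homo sapiens) (on this read-out lower numbers stand for stronger inhibition and higher numbers for weaker inhibition), gives > 10000 nM, which is a limit of the assay and not a number.
Compound 2 `CNc1ncc(C(=O)O)c2nc(-c3ccco3)nn12` in this assay gives > 10000 nM, again a limit of the assay rather than a number.

Compound 2 therefore stands only at a limit in this assay, and compound 1 stands at the same kind of limit; both measured values sit at the limit of > 10000 nM in this assay, at which 2 of the 2 values shown sit. Within the data shown here, no step between measured compounds is on hand, since compound 1 and compound 2 differ in more than one place, so the two values show only that neither reached a measurable inhibition constant.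

Compound 3 `O=C(O)c1cnc(NCc2ccc(Cl)cc2)n2nc(-c3ccco3)nc12` differs from compound 2 by one change: 4-chlorophenyl in place of hydrogen on a saturated chain carbon bound to a nitrogen on an aromatic ring. Among the measured compounds shown here, nothing among the measured compounds tells what this replacement does in this assay. The step from compound 2 to compound 3 is nevertheless expected to run toward stronger inhibition, estimated at an at least 3.3-fold lower number from compound 2 to compound 3 (0.52 log units; beyond the scatter), with a real chance that compound 3 also returns only a limit. Compound 3 is expected to give an inhibition constant near 3000 nM, in a range from 300 nM to 20000 nM.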

Compound 3, inhibition constant: > 30000 nM
Compound 3: a limit, no number (the forecaster's own chance of this, stated with the estimate: 40%); at least 10-fold (1.00 log units) between middle value and limit.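

Among these compounds, compound 2 and compound 3 both stand only at limits in this assay, so no step between them can be read. The compounds shown leave open whether 4-chlorophenyl in place of hydrogen on a saturated chain carbon bound to a nitrogen on an aromatic ring changes inhibition at all, and none of them gives a number.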